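Pyridin-2-yl amide in place of the bromofluorophenyl amide

A few compounds are considered here, and "the series" means these few. Any claim that something is new, unique, unknown or untested is made for them only; others in the source may bear on it.

Two compounds of the series carry results in an assay on isolated protein for inhibition of histone deacetylase 8 (Homo sapiens), with a stated time of 1 h; on this read-out lower numbers stand for stronger inhibition and higher numbers for weaker inhibition. Compound 1 `CCOc1ccc2nc(NC(=O)COc3ccc4cc(/C=C5/SC(=O)NC5=O)ccc4c3)sc2c1` gives 17000 nM. Compound 2 `O=C(COc1ccc2cc(/C=C3/SC(=O)NC3=O)ccc2c1)Nc1ccc(Br)cc1F` returns only a limit, > 50000 nM, so no number is known for it. Compound 2 thus sits at the limit of > 50000 nM in this assay, at which 1 of the 2 values shown sits, the edge of what this assay resolves. Within the data shown here, compound 1 is the one compound with a measured figure. Among the measured compounds shown here, no two measured compounds differ in a single place, so no measured step is available to calibrate a change at the amide nitrogen.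

Compound 3 `O=C(COc1ccc2cc(/C=C3/SC(=O)NC3=O)ccc2c1)Nc1ccccn1` differs from compound 2 by pyridin-2-yl in place of 4-bromo-2-fluorophenyl on an amide-type nitrogen. With one limit and one weak number, nothing in the series anchors the direction of this change. The expectation is a step of modest size toward stronger inhibition, with a fair chance that this assay again reports only a limit. Taken as a step, the expected change reads an at least 1.2-fold lower number from compound 2 to compound 3 (0.09 log units; that floor lies within the scatter). Compound 3 is estimated at 40000 nM, with a range from 12000 nM to 100000 nM.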

Compound 3, half-maximal inhibitory concentration: > 50000 nM
Compound 3: no number, only a limit; the forecaster's own chance of this, stated with the estimate: 50%; middle value at least 1.2-fold (0.09 log units) from the limit.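

In this assay compound 3 gives only a limit, > 50000 nM, and compound 2 also gives only a limit, so no step can be read between compound 2 and compound 3: the limit of > 50000 nM in this assay, at which 2 of the 3 values shown sit.

Left open is whether pyridin-2-yl in place of 4-bromo-2-fluorophenyl on an amide-type nitrogen changes inhibition at all, and in which direction.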